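Swapping an Ethoxyphenyl for a Methoxypyridinyl Amide Group

The compounds below may be only part of what the source reports. "The series", "measured", "known", "first", "only" and "open" are said of these compounds alone.

Three amides built on a shared core have been measured in an assay on CHO cells for agonist activity at G protein-coupled receptor GPR35 (Rattus norvegicus), read by a beta-galactosidase reporter and beta-arrestin recruitment, with a stated time of 90 min; a higher number here means that more compound is needed for the effect, a lower number that less compound is needed. Compound 1 `COc1ccc(C(=O)Nc2cc(Br)cc3c(=O)cc(C(=O)O)oc23)c(Cl)c1` gives 4170 nM, compound 2 `Cc1cccc(C(=O)Nc2cccc3c(=O)cc(C(=O)O)oc23)c1` gives 2750 nM, and compound 3 `CCOc1ccc(C(=O)Nc2cc(Br)cc3c(=O)cc(C(=O)O)oc23)cc1` gives 1360 nM, the lowest of the three and beyond the scatter from both others. Within the data shown here, the only single-point step measured so far, a 3.1-fold lower number from compound 1 to compound 3 (0.49 log units; beyond the scatter), exchanged the aryl group on the carbonyl carbon, and the move to compound 4 `COc1ccc(C(=O)Nc2cc(Br)cc3c(=O)cc(C(=O)O)oc23)cn1` does the same: 6-methoxypyridin-3-yl in place of 4-ethoxyphenyl on a carbonyl carbon. That earlier step bears on this one only loosely, since it swapped a different pair of rings. Lacking a closer precedent, the step expected in this assay is small, a 1.5-fold higher number from compound 3 to compound 4 (0.17 log units; within the scatter), and may sit within the scatter. Compound 4 is estimated at 2000 nM, between 800 nM and 5000 nM.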

Compound 4, half-maximal effective concentration: 991 nM
Compound 4: middle estimate off by 2.0-fold (0.30 log units), on the high side; the measured number falls inside the stated range.
By their numbers in this assay, from the lowest: compounds 4 and 3 (each within the scatter of the next); then compounds 2 and 1 (each within the scatter of the next).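

In this assay this place on the carbonyl carbon takes a 6-methoxypyridin-3-yl as well as a 4-ethoxyphenyl, with a 1.4-fold lower number from compound 3 to compound 4 (0.14 log units; within the scatter) even though the ring and the chain on it both change. The 6-methoxypyridin-3-yl also holds the gain over the 2-chloro-4-methoxyphenyl, with a 4.2-fold lower number from compound 1 to compound 4 (0.62 log units; beyond the scatter) as the step. Nothing available explains either step.

On these data alone, since ring and chain changed together, their separate shares remain unknown, and a 6-ethoxypyridin-3-yl would pull them apart. As far as these compounds go, how an amine in place of the methoxy would fare also stays open.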